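From an amino group to a selenium-bearing group

The source may hold more compounds than are shown below. What is called first, only, known or untested is meant among the compounds shown, and "the series" means these compounds.

In a functional assay on A2780 cells (Homo sapiens) for antiproliferative activity, read by MTT assay, with a stated time of 48 h (a lower number here means a stronger inhibitor, a higher number a weaker inhibitor), compound 1 (`COc1ccc2c(/C=C/C(=O)c3cc(N)c(OC)c(OC)c3)c[nH]c2c1`) gives 204 nM and compound 2 (`COc1ccc2c(/C=C/C(=O)c3cc(N)c(OC)c(OC)c3)cn(C)c2c1`) gives 156 nM. For the measured compounds named here, the one measured step, a 1.3-fold lower number from compound 1 to compound 2 (0.12 log units; within the scatter), places methyl in place of hydrogen on an aromatic nitrogen and leaves the amino group untouched. Compound 3 (`COc1ccc2c(/C=C/C(=O)c3cc(OC)c(OC)c([Se]C)c3)c[nH]c2c1`) differs from compound 1 by a group of 2 heavy atoms (1 carbon, 1 selenium; no ring) in place of one nitrogen atom, on an aromatic carbon, on an aromatic carbon ortho to a methoxy group. Going by the values given here, no measured step covers this exchange, so no direction can be drawn for this assay, and no shift beyond the scatter is assumed. The expected change is a 1.1-fold higher number from compound 1 to compound 3 (0.03 log units; within the scatter). For compound 3 the estimated value is 220 nM, within an expected range of 45 nM to 1000 nM.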

Compound 3, half-maximal inhibitory concentration: 65 nM
Compound 3: middle estimate off by 3.4-fold (0.53 log units), on the high side; the range from low to high includes it.
By their numbers in this assay, from the lowest: compound 3; then compounds 2 and 1 (each within the scatter of the next).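

In this assay, the exchange of the amino group for the group of 1 carbon and 1 selenium, on an aromatic carbon ortho to a methoxy group, gives a 3.1-fold lower number from compound 1 to compound 3 (0.50 log units; beyond the scatter). This shows that the number responds to a change at this position, which the earlier step left untouched. It also shows that compound 3 gets there with 0 hydrogen-bond donors and 0 hydrogen-bond acceptors in the entering group, but nothing at hand explains the shift.

Still open, as far as these compounds go, is whether the selenium itself matters, or whether a methylthio group or an ethyl group in the same place would give a similar number. Also open, from the compounds shown here alone, is how methyl on the aromatic nitrogen would behave alongside the selenium-bearing group.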